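Ester variation on a dihydropyridine L-type calcium channel series

A few compounds are considered here, and "the series" means these few. Any claim that something is new, unique, unknown or untested is made for them only; others in the source may bear on it.

Two compounds in this series carry a measured value. Compound 1, `CCOC(=O)C1=C(C)NC(/C=C/C#N)=C(C(=O)OCC)C1c1cccc([N+](=O)[O-])c1`, in a functional assay on HEK293 cells for antagonist activity at Voltage-dependent L-type calcium channel subunit alpha-1D (Rattus norvegicus), read by FLIPR (a lower number here means a stronger inhibitor, a higher number a weaker inhibitor), gives 45 nM. Compound 2, `COC(=O)C1=C(C)NC(C)=C(C(=O)OCc2ccc(F)c(F)c2)C1c1cccc([N+](=O)[O-])c1`, in this assay gives 20 nM, the lower of the two numbers; the gap between compound 1 and compound 2 lies beyond the scatter of repeated measurements, so compound 2 stands as the stronger inhibitor of the pair. No single-point change between measured compounds is available, so the next step rests on compound 2 alone.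

Compound 3, `COC(=O)C1=C(C)NC(C)=C(C(=O)OCCCCc2ccc(OC)cc2)C1c1cccc([N+](=O)[O-])c1`, differs from compound 2 only in the ester: 3-(4-methoxyphenyl)propyl in place of 3,4-difluorophenyl on a saturated chain carbon bound to an oxygen next to a carbonyl group. Nothing measured here tells how this place responds to such a replacement. The expected step from compound 2 to compound 3 in this assay is a modest rise, a 2.0-fold higher number from compound 2 to compound 3 (0.30 log units; within the scatter), close to the edge of the scatter. For compound 3 the estimate in this assay is 40 nM, with a range from 10 nM to 160 nM.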

Compound 3, half-maximal inhibitory concentration: 38 nM
For compound 3 the middle estimate is 1.1-fold (0.02 log units) above the measured one, within the range that was stated.
By their numbers in this assay, from the lowest: compounds 2, 3 and 1 (each within the scatter of the next, the first and the last beyond it).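

In this assay this place takes 3-(4-methoxyphenyl)propyl in place of 3,4-difluorophenyl with a 1.9-fold higher number from compound 2 to compound 3 (0.28 log units; within the scatter) and so compound 2 and compound 3 cannot be told apart. Among these compounds, this is the first reading at this place: an entering group of 11 heavy atoms, with 1 hydrogen-bond acceptor, is tolerated against a leaving group of 8 heavy atoms with none, as far as this single pair shows. No measurement bears on why the two esters read alike.

Because the aromatic ring and the chain change together, this pair cannot show what each contributes alone. On these data alone, whether this place also tolerates an amine or a carboxylic acid at the end of the chain remains open.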